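A few compounds are considered here, and "the series" means these few. Any claim that something is new, unique, unknown or untested is made for them only; others in the source may bear on it.

Among the compounds with values here, in a functional assay on SK-MEL-147 cells (Homo sapiens) for cytotoxicity, read by MTT assay, with a stated time of 24 h (on this read-out lower numbers stand for an effect already at smaller amounts and higher numbers for an effect only at larger amounts of compound), two compounds with the same core have numbers so far. Compound 1 `CCOC(=O)c1cc([Se]c2ccccc2)c2cc(Cl)ccc2n1`, which carries a chloro group, gives 47100 nM. Compound 2 `CCOC(=O)c1cc([Se]c2ccccc2)c2cc(C)ccc2n1`, which carries a methyl group instead, gives 12000 nM, the lower of the two numbers. Compound 3 `CCOC(=O)c1cc([Se]c2ccccc2)c2ccccc2n1` has not yet been measured. It has hydrogen in place of methyl on an aromatic carbon. Within the data shown here, only one measured step bears on this change: a 3.9-fold lower number from compound 1 to compound 2 (0.59 log units; beyond the scatter), a modest step with methyl in place of chloro. Among the measured compounds shown here, that step shows the group at this place can shift the number, but no compound with hydrogen there has a value, so the direction is uncertain. The step expected in this assay is a 1.7-fold higher number from compound 2 to compound 3 (0.22 log units; within the scatter), a small rise in the number. For compound 3 the estimate is 20000 nM, with an expected range of 8000 nM to 50000 nM.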

Compound 3, half-maximal effective concentration: 86300 nM
Compound 3: the middle estimate sits 4.3-fold (0.63 log units) below what was measured; measured number outside the range, above it.
By their numbers in this assay, from the lowest: compound 2; then compounds 1 and 3 (each within the scatter of the next).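

In this assay the compound with hydrogen gives this position a baseline, and against it the methyl group stands out: the change shows a 7.2-fold higher number from compound 2 to compound 3 (0.86 log units; beyond the scatter) when hydrogen replaces methyl on this aromatic carbon. Chloro cannot be told apart from hydrogen here, since a 1.8-fold higher number from compound 1 to compound 3 (0.26 log units; within the scatter) stays within the scatter. The earlier step from chloro to methyl therefore marks methyl, not chloro, as the group that stands apart at this place. No measured evidence says why methyl differs from the other two.

On these data alone, whether the lower number belongs to methyl alone or extends to an ethyl group or a longer chain at this place stays open. So does the effect of a methoxy group or an amine there.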